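The source may hold more compounds than are shown below. What is called first, only, known or untested is meant among the compounds shown, and "the series" means these compounds.

Compound 1 `COc1cccc(OC)c1OCCNCCOc1ccccc1OCc1ccc([N+](=O)[O-])cc1` gives 9.41 in a functional assay on thoracic aorta for antagonist activity at Alpha-1D adrenergic receptor (Rattus norvegicus); on this read-out higher numbers stand for higher potency (the scale is a negative logarithm) and lower numbers for lower potency.
Compound 2 `COc1cccc(COc2ccccc2OCCNCCOc2c(OC)cccc2OC)c1` gives 9.12 in this assay.

Only these two compounds have been measured. Compound 2 is separated from compound 1 by the step of a number 0.29 log units lower from compound 1 to compound 2 (within the scatter), which lies within the scatter, so the two compounds cannot be told apart on this read-out. The unmeasured compound 3 `COc1cccc(OC)c1OCCNCCOc1ccccc1OCc1ccc(OC(C)C)cc1` differs from compound 2 only by 4-isopropoxyphenyl in place of 3-methoxyphenyl on a saturated chain carbon bound to an oxygen on an aromatic ring. Among the measured compounds shown here, the single measured step that bears on this change is the one from compound 1 to compound 2, where the group at the same place was exchanged, and that step stayed within the scatter. With no evidence of a shift at this position, compound 3 is expected to give a number close to that of compound 2, with a step of a number 0.02 log units lower from compound 2 to compound 3 (within the scatter) that is not expected to exceed the scatter. The estimate for compound 3 in this assay is therefore 9.1, with a range from 8.6 to 9.6.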

Compound 3, negative logarithm of the antagonist equilibrium constant: 9.14
Estimate against measurement, compound 3: 0.04 log units below, and the stated range covers the measured number.
By their numbers in this assay, from the lowest: compounds 2, 3 and 1 (each within the scatter of the next).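

In this assay, the exchange of 3-methoxyphenyl for 4-isopropoxyphenyl on a saturated chain carbon bound to an oxygen on an aromatic ring gives a step within the scatter (a number 0.02 log units higher from compound 2 to compound 3 (within the scatter)), and so does isopropoxy in place of nitro on an aromatic carbon (a number 0.27 log units lower from compound 1 to compound 3 (within the scatter)). Among the compounds shown here, three different aryl groups at this place, 4-nitrophenyl, 3-methoxyphenyl and 4-isopropoxyphenyl, now cannot be told apart on this read-out, where the earlier compounds offered only two, and no compound among the three goes against this. Nothing available explains why these exchanges leave the number unmoved.

From the compounds shown here alone, whether a phenyl group carrying an amine or a carboxylic acid at this place would give a step beyond the scatter remains open. So does whether a plain phenyl group or a longer chain in place of the isopropoxy group would hold the number as well.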